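This account rests on a few compounds, and the source may have more. Where it says the series, first, only, none or still open, it means among the compounds named here.

Of the compounds shown here, two have been measured in an assay on nucleic acid for binding affinity to Calf thymus DNA (Bos taurus); a lower number here means a stronger inhibitor, a higher number a weaker inhibitor. Compound 1 `CCN(CC)CCn1c2ccc3ccccc3c2c2nc3ccccc3nc21` gives 20400 nM. Compound 2 `CCCN(CCC)CCn1c2ccc3ccccc3c2c2nc3ccccc3nc21` gives 15800 nM. Among the measured compounds shown here, the one step between them, a 1.3-fold lower number from compound 1 to compound 2 (0.11 log units; within the scatter), falls within the scatter, so compound 2 holds the lower of the two numbers without being separated from compound 1.

Compound 3 `c1ccc2c(c1)ccc1c2c2nc3ccccc3nc2n1CCN1CCCCC1` is not yet measured. It follows from compound 2 by piperidin-1-yl in place of dipropylamino on a saturated chain carbon, two bonds along the chain from an aromatic nitrogen. For the measured compounds named here, only one measured step bears on this change, a 1.3-fold lower number from compound 1 to compound 2 (0.11 log units; within the scatter): it also reworked the amine on the same saturated chain carbon, two bonds along the chain from an aromatic nitrogen, and moved the number by no more than the scatter. Nothing in the series shows what closing the amine into a six-membered non-aromatic ring does. The step expected here, a 1.0-fold higher number from compound 2 to compound 3 (0.01 log units; within the scatter), is therefore one of no size beyond the scatter, in neither direction. For compound 3 the estimate in this assay is 16000 nM, expected to lie between 8000 nM and 32000 nM.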

Compound 3, half-maximal inhibitory concentration: 30900 nM
Compound 3: middle estimate off by 1.9-fold (0.29 log units), on the low side; the measured number falls inside the stated range.
By their numbers in this assay, from the lowest: compounds 2, 1 and 3 (each within the scatter of the next).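

In this assay, among the compounds shown here, the amine on the saturated chain carbon, two bonds along the chain from an aromatic nitrogen, has now been closed into a six-membered non-aromatic ring for the first time. The step of a 2.0-fold higher number from compound 2 to compound 3 (0.29 log units; within the scatter) and the step of a 1.5-fold higher number from compound 1 to compound 3 (0.18 log units; within the scatter) both lie within the scatter, so piperidin-1-yl is not separated from dipropylamino or from diethylamino, and the ring adds a second kind of change at this place that leaves the three compounds unresolved. No measurement at hand gives a reason for this result.

As far as these compounds go, compounds 1, 2 and 3 cover only diethylamino, dipropylamino and piperidin-1-yl, all carried on the same 2-aminoethyl chain, so it remains open whether any amine at this place can move the number beyond the scatter. A morpholine or a piperazine in place of the piperidine, a pyrrolidine with its smaller ring, or a longer propyl chain between the aromatic nitrogen and the amine would each test this, since a step beyond the scatter has yet to appear among the compounds shown.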